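Benzyl Substitution on the Ring Amide Nitrogen: Compound 3 Outlook

The source may report more compounds than this note shows. Statements on the series, on what has been measured and on what is new or still open speak of the compounds shown alone.

Among the measured compounds shown here, compound 1 `O=C1Nc2ccc(Br)cc2/C1=N/NC(=S)Nc1ccc(Cl)cc1` gives 29000 nM in a functional assay on MOLT-4 cells (Homo sapiens), with a stated time of 72 h (on this read-out lower numbers stand for stronger inhibition and higher numbers for weaker inhibition), the higher of the two numbers measured so far. Compound 2 `O=C1Nc2ccc(F)cc2/C1=N/NC(=S)Nc1ccc(Cl)cc1` gives 14000 nM in this assay; the step of a 2.1-fold lower number from compound 1 to compound 2 (0.32 log units; beyond the scatter) is the only measured one. Compound 3 `O=C1/C(=N\NC(=S)Nc2ccc(Cl)cc2)c2cc(Br)ccc2N1Cc1ccc(F)cc1` differs from compound 1 by 4-fluorobenzyl in place of hydrogen on an amide-type nitrogen in a ring. For the measured compounds named here, no measured step touches the amide-type nitrogen in the ring, so the bromo-to-fluoro step offers no guide, and no step beyond the scatter is expected in this assay for this change. Compound 3 is therefore estimated at 20000 nM, range 5000 nM to 80000 nM, which means an expected step of a 1.5-fold lower number from compound 1 to compound 3 (0.16 log units; within the scatter).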

Compound 3, half-maximal inhibitory concentration: 48000 nM
Compound 3: middle estimate off by 2.4-fold (0.38 log units), on the low side; measured number inside the range.
By their numbers in this assay, from the lowest: compound 2; then compounds 1 and 3 (each within the scatter of the next).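

With 4-fluorobenzyl in place of hydrogen on the amide-type nitrogen in a ring, this assay shows a 1.7-fold higher number from compound 1 to compound 3 (0.22 log units; within the scatter) as the first read on this position. On the core of compound 1, the amide hydrogen can therefore give way to this much larger group with no step beyond the scatter. No measured evidence explains this result.

As far as these compounds go, whether the same change holds on the fluoro core of compound 2 remains open. Also open, from the compounds shown here alone, is whether a methyl group, or a longer chain ending in an amine, on this nitrogen would move the number beyond the scatter.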